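Series notes: hydroxy for trifluoromethoxy on the methylated core

The source may report more compounds than this note shows. Statements on the series, on what has been measured and on what is new or still open speak of the compounds shown alone.

Three compounds are in hand. Compound 1 `FC(F)(F)Oc1ccc(-c2ccc(-c3ccc(-c4nc5ccccc5[nH]4)cc3)cc2)cc1` gives 100000 nM in a functional assay on DWD cells (Homo sapiens) for inhibition, read by sulforhodamine B assay; a higher number here means a weaker inhibitor of growth, a lower number a stronger inhibitor of growth. Compound 2 `Oc1ccc(-c2ccc(-c3ccc(-c4nc5ccccc5[nH]4)cc3)cc2)cc1` gives 46300 nM in this assay; the change from compound 1 is hydrogen in place of trifluoromethyl on an oxygen on an aromatic ring and the step is a 2.2-fold lower number from compound 1 to compound 2 (0.33 log units; beyond the scatter). Compound 3 `Cc1ccc2[nH]c(-c3ccc(-c4ccc(-c5ccc(OC(F)(F)F)cc5)cc4)cc3)nc2c1` gives 41100 nM in this assay; its core differs from the core of compound 1 by methyl in place of hydrogen on an aromatic carbon and the step is a 2.4-fold lower number from compound 1 to compound 3 (0.39 log units; beyond the scatter). Compound 2 and compound 3 sit within the scatter of each other, so no order between them is claimed.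

Compound 4 `Cc1ccc2[nH]c(-c3ccc(-c4ccc(-c5ccc(O)cc5)cc4)cc3)nc2c1` is not yet measured. It differs from compound 3 by hydrogen in place of trifluoromethyl on an oxygen on an aromatic ring, the same change that took compound 1 to compound 2, now made on the core of compound 3. Among the measured compounds this change occurs once, with the size of a 2.2-fold lower number from compound 1 to compound 2 (0.33 log units; beyond the scatter). Whether it carries over to the methylated core rests on that single pair alone. The step for compound 4 is expected to be about a 2.2-fold lower number from compound 3 to compound 4 (0.34 log units; beyond the scatter) in this assay, in line with a 2.2-fold lower number from compound 1 to compound 2 (0.33 log units; beyond the scatter). Compound 4 is therefore estimated at 19000 nM, with a likely range from 8000 nM to 45000 nM.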

Compound 4, concentration for 50% growth inhibition: 21200 nM
The estimate for compound 4 lay 1.1-fold (0.05 log units) below the measured number; measured number inside the range.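

In this assay, hydrogen in place of trifluoromethyl on the methylated core gives a 1.9-fold lower number from compound 3 to compound 4 (0.29 log units; within the scatter), a step that on its own does not clear the scatter but agrees with the step on the unmethylated core: the same change on two cores in this assay, a 2.2-fold lower number (0.33 log units; beyond the scatter) from compound 1 to compound 2 and a 1.9-fold lower number (0.29 log units; within the scatter) from compound 3 to compound 4, 1.1-fold (0.05 log units) apart, within the scatter of two such steps. Read the other way, methyl in place of hydrogen on an aromatic carbon gives a 2.2-fold lower number from compound 2 to compound 4 (0.34 log units; beyond the scatter), and this step also holds up when the group on the oxygen differs: the same change on two cores in this assay, a 2.4-fold lower number (0.39 log units; beyond the scatter) from compound 1 to compound 3 and a 2.2-fold lower number (0.34 log units; beyond the scatter) from compound 2 to compound 4, 1.1-fold (0.05 log units) apart, within the scatter of two such steps. The four compounds therefore show the two changes carrying over between these two cores with little difference in size, but each comparison rests on a single pair of small steps, so this does not show transfer to any other core and gives no reason for the effect.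

From the compounds shown here alone, whether an amine or a carboxylic acid in place of the hydroxy would follow the same pattern stays open. So does whether a longer chain in place of the methyl would leave the step from the oxygen substituent unchanged.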